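Chloro for fluoro in the (2-fluorophenyl)amino group

This account rests on a few compounds, and the source may have more. Where it says the series, first, only, none or still open, it means among the compounds named here.

The series shares the core of compound 1 `C=CC(=O)Nc1cccc(NC(=O)CSc2nc(Nc3ccccc3)c3ccccc3n2)c1`. In a functional assay on MDA-MB-231 cells (Homo sapiens) for inhibition, read by MTT assay, with a stated time of 72 h (a higher number here means a weaker inhibitor, a lower number a stronger inhibitor), compound 1 gives 10200 nM, compound 2 `O=C(CSc1nc(Nc2ccccc2)c2ccccc2n1)Nc1ccc(Br)cc1` gives 11500 nM, and compound 3 `C=CC(=O)Nc1cccc(NC(=O)CSc2nc(Nc3ccccc3F)c3ccccc3n2)c1` gives 18700 nM. Compound 3 stands at the highest of the three numbers, but its gaps to compound 2 and to compound 1 both lie within the scatter; a 1.1-fold higher number from compound 1 to compound 2 (0.05 log units; within the scatter) and a 1.8-fold higher number from compound 1 to compound 3 (0.26 log units; within the scatter) are likewise within it. Compound 4 `C=CC(=O)Nc1cccc(NC(=O)CSc2nc(Nc3ccccc3Cl)c3ccccc3n2)c1` differs from compound 3 by chloro in place of fluoro on an aromatic carbon. Among the measured compounds shown here, no measured step swaps one halogen for another; the only step touching this aromatic carbon is a 1.8-fold higher number from compound 1 to compound 3 (0.26 log units; within the scatter), within the scatter. A step of a 1.1-fold lower number from compound 3 to compound 4 (0.04 log units; within the scatter) is therefore expected, none beyond the scatter. Compound 4 is estimated at 17000 nM, ranging from 7000 nM to 40000 nM.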

Compound 4, half-maximal inhibitory concentration: 12700 nM
Beside the measured number, compound 4's estimate is 1.3-fold (0.13 log units) above it; the range from low to high includes it.
By their numbers in this assay, from the lowest: compounds 1, 2, 4 and 3 (each within the scatter of the next).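

Among the compounds shown here, at this aromatic carbon, ortho to a large group, chloro in place of fluoro gives the first halogen-for-halogen step in this assay (a 1.5-fold lower number from compound 3 to compound 4 (0.17 log units; within the scatter)), and it lies within the scatter. Chloro in place of hydrogen (a 1.2-fold higher number from compound 1 to compound 4 (0.10 log units; within the scatter)) also lies within the scatter, so neither halogen at this carbon has moved the number beyond the scatter from the unsubstituted compound 1. No measurement bears on the reason for these values.

Open remain a methoxy group or an amine at this carbon, either of which could test whether the position tolerates more than a halogen. Also open, from the compounds shown here alone, is whether chloro on another carbon of this ring reads the same.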